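Swapping a chloro for a methyl on a shared pyrazole core

This account rests on a few compounds, and the source may have more. Where it says the series, first, only, none or still open, it means among the compounds named here.

Within the data shown here, compound 1 `Clc1ccc(-c2cc(-c3ccc(Cl)cc3)[nH]n2)cc1` is one of two compounds measured in an assay on mitochondria from brain for inhibition of Amine oxidase [flavin-containing] A (Bos taurus), read by fluorescence; a lower number here means a stronger inhibitor, a higher number a weaker inhibitor; in this assay compound 1 gives 2.04 nM, the lower of the two numbers. Among the measured compounds shown here, its only measured neighbour is compound 2 `Fc1ccc(-c2cc(-c3ccc(Cl)cc3)n[nH]2)cc1`, which in this assay gives 3.02 nM. For the measured compounds named here, the one measured step, a 1.5-fold higher number from compound 1 to compound 2 (0.17 log units; within the scatter), replaces a chloro with a fluoro on an aromatic carbon and stays within the scatter.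

Compound 3 `Cc1ccc(-c2cc(-c3ccc(Cl)cc3)[nH]n2)cc1` has not yet been measured. It differs from compound 1 by methyl in place of chloro on an aromatic carbon, with the methyl entering on an aromatic carbon of a six-membered aromatic ring of carbon only, para to a large group. Going by the values given here, the only step that bears on this change is the one from compound 1 to compound 2, and it was small. Since that step stayed within the scatter, the expectation for compound 3 is a step of similar size, a 1.5-fold higher number from compound 1 to compound 3 (0.17 log units; within the scatter), with no direction beyond the scatter that the data would support. The estimate for compound 3 in this assay is therefore 3 nM, with a range from 1.2 nM to 8 nM.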

Compound 3, half-maximal inhibitory concentration: 3020 nM
Beside the measured number, compound 3's estimate is 1000-fold (3.00 log units) below it; measured number above the stated range.
By their numbers in this assay, from the lowest: compounds 1 and 2 (each within the scatter of the next); then compound 3.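

In this assay this position, on a six-membered aromatic ring of carbon only and para to a large group, proves highly sensitive to the group it carries: the change of chloro to methyl gives a 1500-fold higher number from compound 1 to compound 3 (3.17 log units; beyond the scatter) even though each group counts as 1 heavy atom. The earlier step, a 1.5-fold higher number from compound 1 to compound 2 (0.17 log units; within the scatter) and within the scatter, had shown only that fluoro and chloro could not be told apart here, so the latitude it suggested holds for that pair and does not extend to methyl. Nothing available accounts for the size of the methyl step.

The compounds shown leave open where other groups at this position would fall in the wide gap between chloro and methyl, for example a methoxy, a nitrile, an amine or a longer chain such as ethyl. They also leave open whether bromo would stay with chloro and fluoro, and whether the chloro on the other ring, kept in all three compounds, is just as sensitive to replacement by methyl.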